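Swapping the phenylpiperazine for a dibutylamine

The source may report more compounds than this note shows. Statements on the series, on what has been measured and on what is new or still open speak of the compounds shown alone.

The series of sulfonyl ethers examined here comprises three measured compounds and one awaiting a result. Compound 1 `CC(C)c1cn2ccccc2c1S(=O)(=O)c1ccc(OCCCN2CCN(c3ccccc3)CC2)cc1` gives 205 nM in a functional assay (aorta) with Rattus norvegicus as the target (on this read-out lower numbers stand for stronger inhibition and higher numbers for weaker inhibition), the lowest number of the three. Compound 3 `CCCN(CCC)CCCOc1ccc(S(=O)(=O)c2c(C)cn3ccccc23)cc1` gives 957 nM in this assay, and compound 2 `CCCCCCCCN(CCCCCCCC)CCCOc1ccc(S(=O)(=O)c2c(C(C)C)cn3ccccc23)cc1` gives 30100 nM, both clearly higher than compound 1 by more than the scatter, so compound 1 stands as the most potent of the measured set.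

Compound 4 `CCCCN(CCCC)CCCOc1ccc(S(=O)(=O)c2c(C(C)C)cn3ccccc23)cc1` has not yet been measured. It differs from compound 1 in one place: dibutylamino in place of 4-phenylpiperazin-1-yl on a saturated chain carbon, three bonds along the chain from an oxygen on an aromatic ring. Within the data shown here, no directly comparable step between measured compounds exists, yet the two measured dialkylamines, compound 3 and compound 2, both return weaker numbers than compound 1, which carries the cyclic amine.

On that basis, a loss of potency beyond the scatter is expected for compound 4, with a step of a 7.3-fold higher number from compound 1 to compound 4 (0.86 log units; beyond the scatter). Compound 4 is estimated at 1500 nM, within a range of 500 nM to 5000 nM.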

Compound 4, half-maximal inhibitory concentration: 21.6 nM
Compound 4: the middle estimate sits 69-fold (1.84 log units) above what was measured, and the stated range ends above it.
By their numbers in this assay, from the lowest: compound 4; then compound 1; then compound 3; then compound 2.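

In this assay, dibutylamino in place of 4-phenylpiperazin-1-yl gives a 9.5-fold lower number from compound 1 to compound 4 (0.98 log units; beyond the scatter), so at this place on the chain a ring is not needed for a low number, and an open-chain amine can surpass the phenylpiperazine. Length of the alkyl chains on the amine matters here as well: compound 4 gives 21.6 nM, whereas compound 2, which has dioctylamino at the same place on the same core, gives 30100 nM. The higher number of compound 2 therefore belongs to that particular amine and does not extend to dialkylamines as a class.

The compounds shown offer no measurement that would explain the effect of this change. They also leave open where between the butyl and octyl chains the numbers begin to rise, and how a dihexylamino group or a piperidine ring would read at this place on the same core.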